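Spiro series: terminal chain change from compound 2 to compound 4

The source may report more compounds than this note shows. Statements on the series, on what has been measured and on what is new or still open speak of the compounds shown alone.

Measured so far in an assay on HEK293 cells for displacement of a labelled ligand from NPC1-like intracellular cholesterol transporter 1 (Homo sapiens); a higher number here means a weaker inhibitor, a lower number a stronger inhibitor:
compound 1 `O=C(CN1CN(c2ccccc2)C2(CCN(C(=O)c3ccc(C4CCCCC4)cc3)CC2)C1=O)N1CCC(CO)CC1`: 1100 nM
compound 2 `CC(C)(C)c1ccc(C(=O)N2CCC3(CC2)C(=O)N(CC(=O)NCN)CN3c2ccccc2)cc1`: 26500 nM
compound 3 `CC(C)(C)OC(=O)NC1CCN(C(=O)CN2CN(c3ccccc3)C3(CCN(C(=O)c4ccc(C5CCCCC5)cc4)CC3)C2=O)CC1`: 4800 nM

Compound 2 gives the highest number of the three; compound 3 comes nearest to it, and compound 1 is furthest away. Both gaps are beyond the scatter, so compound 2 is the weakest inhibitor here.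

The unmeasured compound 4 `CC(C)(C)c1ccc(C(=O)N2CCC3(CC2)C(=O)N(CC(=O)NCCCNS(C)(=O)=O)CN3c2ccccc2)cc1` keeps the tert-butyl aryl amide and the shared core of compound 2 and differs only at the end of the side chain: 2-(methanesulfonamido)ethyl in place of amino on a saturated chain carbon bound to an amide-type nitrogen.

Among the measured compounds shown here, only one measured step exists, a 4.4-fold higher number from compound 1 to compound 3 (0.64 log units; beyond the scatter). It changes a substituent on a saturated ring carbon in a different part of the molecule, so it bears only loosely on the present change, showing that a larger group at a chain end can cost potency in this assay. For the measured compounds named here, no measured pair changes the aminomethyl-amide end, so the direction for compound 4 is open. Compound 1, with its longer chain carrying a hydroxymethyl, sits well below compound 2, which weakly suggests that an extended chain with a hydrogen-bond donor and acceptors is tolerated. Compound 4 is therefore expected to give a somewhat lower number, estimated at 10000 nM, with a range of 2500 nM to 40000 nM, corresponding to an expected step of a 2.7-fold lower number from compound 2 to compound 4 (0.42 log units; beyond the scatter).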

Compound 4, half-maximal inhibitory concentration: 10400 nM
The estimate for compound 4 lay 1.0-fold (0.02 log units) below the measured number; measured number inside the range.
By their numbers in this assay, from the lowest: compound 1; then compound 3; then compound 4; then compound 2.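

In this assay the end of the side chain now has its first measured step: 2-(methanesulfonamido)ethyl in place of amino, on a saturated chain carbon bound to an amide-type nitrogen, gives a 2.5-fold lower number from compound 2 to compound 4 (0.41 log units; beyond the scatter) and so a stronger inhibitor. Among the compounds shown here, this position therefore takes a much larger group with a gain in potency, whereas the one earlier step, at a saturated ring carbon elsewhere in the molecule, runs the other way with a 4.4-fold higher number from compound 1 to compound 3 (0.64 log units; beyond the scatter) as hydroxymethyl gives way to the larger (tert-butoxycarbonyl)amino, so group size alone sets no rule across the two sites. No measurement at hand accounts for the gain at the chain end.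

For the compounds shown here, the single step changes the chain length and the terminal group together, so a propyl chain ending in a primary amine, or a methanesulfonamide on a shorter chain, would be needed to tell which of the two carries the gain. Also open, going by these compounds, is how other chain ends, such as a carboxylic acid or a longer chain, behave at this position, and whether the gain holds with the aryl amide of compound 1.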